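Compound 3: a phenyl amide without a measured neighbour

A few compounds are considered here, and "the series" means these few. Any claim that something is new, unique, unknown or untested is made for them only; others in the source may bear on it.

Results so far in a functional assay on SK-BR-3 cells (Homo sapiens) for cytotoxicity, read by MTT assay, with a stated time of 72 h; a lower number here means a stronger inhibitor, a higher number a weaker inhibitor
- compound 1 `COc1cccc(CNC(=O)c2nc(Br)c3cccnc3c2N[C@H]2CC[C@H](N)CC2)c1` gives 6000 nM
- compound 2 `N[C@H]1CC[C@H](Nc2c(C(=O)NCc3ccccn3)nc(Br)c3cccnc23)CC1` gives "not determined" (no result reported)

Compound 2 has no number to stand on, since in this assay compound 2 is recorded as "not determined" (no result reported) with no result reported. The next structure is compound 3 `N[C@H]1CC[C@H](Nc2c(C(=O)Nc3ccccc3)nc(Br)c3cccnc23)CC1`, reached by phenyl in place of (pyridin-2-yl)methyl on an amide-type nitrogen with phenyl in place of (pyridin-2-yl)methyl on an amide-type nitrogen. Within the data shown here, no step from compound 2 can be sized, and no direction is expected from it. Among the measured compounds shown here, compound 1 at 6000 nM is the only number available, and a result within the scatter of that value is expected. Compound 3 is estimated at 6000 nM within a range of 1500 nM to 25000 nM in this assay for now.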

Compound 3, half-maximal inhibitory concentration: 2000 nM
Estimate against measurement, compound 3: 3.0-fold (0.48 log units) above; measured number inside the range.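

Phenyl in place of 3-methoxybenzyl on an amide-type nitrogen gives a 3.0-fold lower number from compound 1 to compound 3 (0.48 log units; beyond the scatter) in this assay and so shows that the result responds to the group at this position. The step from compound 2 cannot be read, which leaves (pyridin-2-yl)methyl unplaced against phenyl. Nothing available explains the step. The compounds shown leave open whether an amine or a carboxylic acid on the phenyl ring would move the number further. They also leave open what a longer chain on the amide-type nitrogen would do.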